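Varying the Piperazine Substituent on a Chemokine Receptor Antagonist Core

The compounds below may be only part of what the source reports. "The series", "measured", "known", "first", "only" and "open" are said of these compounds alone.

Compound 1 `CN(C[C@H]1Cc2c(cccc2N2CCN(C3CC3)CC2)CN1)[C@H]1CCCc2cccnc21`: 23.5 nM
Compound 2 `c1cnc2c(c1)CCC[C@@H]2N(CC1CC1)C[C@H]1Cc2c(cccc2N2CCNCC2)CN1`: 26.7 nM
Compound 3 `CN(C[C@H]1Cc2c(cccc2N2CCN(c3ncccn3)CC2)CN1)[C@H]1CCCc2cccnc21`: 30.7 nM

Of the compounds shown here, three sharing one core have been measured in a functional assay on CCRF-CEM cells for antagonist activity at C-X-C chemokine receptor type 4 (Homo sapiens), read by calcium flux, with stated times of 25 min and 90 s; a higher number here means a weaker inhibitor, a lower number a stronger inhibitor. Compound 1 gives 23.5 nM, compound 2 gives 26.7 nM, and compound 3 gives 30.7 nM. Compound 1 stands at the lower end of this tight cluster, yet the step of a 1.3-fold higher number from compound 1 to compound 3 (0.12 log units; within the scatter) does not leave the scatter, and the values of compound 1 and compound 2 likewise sit within the scatter of each other.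

The new compound 4 `CN(C[C@H]1Cc2c(cccc2N2CCNC(C)(C)C2)CN1)[C@H]1CCCc2cccnc21` differs from compound 1 in a single place: 3,3-dimethylpiperazin-1-yl in place of 4-cyclopropylpiperazin-1-yl on an aromatic carbon. Among the compounds with values here, compound 2 carries an unsubstituted piperazin-1-yl and also a cyclopropylmethyl group instead of a methyl group, so no single step connects it to compound 1; its value nonetheless shows that the piperazine ring need not carry a further substituent for the number to stay in the same region. Within the data shown here, the only one-place step that bears on compound 4 is a 1.3-fold higher number from compound 1 to compound 3 (0.12 log units; within the scatter), and it is small. Among the measured compounds shown here, the 3,3-dimethyl pattern has no precedent among the measured compounds, so the expectation rests on the tolerance seen so far. The step expected for compound 4 is a 1.3-fold higher number from compound 1 to compound 4 (0.11 log units; within the scatter). The estimate for compound 4 is 30 nM, expected to fall between 12 nM and 80 nM.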

Compound 4, half-maximal inhibitory concentration: 33.9 nM
Compound 4: middle estimate off by 1.1-fold (0.05 log units), on the low side; the range from low to high includes it.
By their numbers in this assay, from the lowest: compounds 1, 2, 3 and 4 (each within the scatter of the next).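

The exchange of 4-cyclopropylpiperazin-1-yl for 3,3-dimethylpiperazin-1-yl on the aromatic carbon gives a 1.4-fold higher number from compound 1 to compound 4 (0.16 log units; within the scatter) in this assay, so this position tolerates more than a change of the substituent on the ring amine nitrogen. Within the data shown here, the only earlier one-place step, a 1.3-fold higher number from compound 1 to compound 3 (0.12 log units; within the scatter), replaced one such substituent with another, whereas this change removes the three-membered carbon ring and brings in a hydrogen-bond donor that the leaving group lacks, and the number still stays within the scatter. The data offer no measured explanation for this tolerance.

The two methyl groups and the unsubstituted ring nitrogen of compound 4 arrive in a single change, and compound 2 differs from compound 4 in more than one place, so their separate contributions remain unresolved. On these data alone, it also remains open whether the same tolerance extends to a morpholine in place of the piperazine, or to a piperazine carrying an acetyl group, a carboxylic acid or a longer chain on its ring nitrogen.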